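This account rests on a few compounds, and the source may have more. Where it says the series, first, only, none or still open, it means among the compounds named here.

Two members of the series have been measured in a functional assay on QGY-7703 cells (Homo sapiens) for cytotoxicity, read by MTT assay, with a stated time of 24 h; on this read-out higher numbers stand for weaker inhibition and lower numbers for stronger inhibition. Compound 1 `CN1C/C(=C\c2ccncc2)C(=O)/C(=C/c2ccccc2F)C1` gives 4900 nM. Compound 2 `CN1C/C(=C\c2ccncc2)C(=O)/C(=C/c2ccccc2C(F)(F)F)C1`, with trifluoromethyl in place of fluoro on an aromatic carbon, gives 4500 nM; the step is a 1.1-fold lower number from compound 1 to compound 2 (0.04 log units; within the scatter). Compound 2 stands at the lower end of the two numbers shown, but its gap to compound 1 is within the scatter, so no order between them is claimed.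

Compound 3 `O=C1/C(=C/c2ccncc2)CN(S(=O)(=O)c2ccc(Cl)cc2)C/C1=C\c1ccccc1C(F)(F)F` is not yet measured. Against compound 2 the change is (4-chlorophenyl)sulfonyl in place of methyl on an amine nitrogen in a ring. Going by the values given here, no measured step touches the amine nitrogen in a ring; the only step so far concerns the aromatic carbon and was within the scatter. Nothing therefore fixes size or direction of the step in this assay, and the expected step is a 1.1-fold lower number from compound 2 to compound 3 (0.05 log units; within the scatter), set at no change beyond the scatter with a wide range. Compound 3 is expected to give about 4000 nM, between 1000 nM and 16000 nM.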

Compound 3, half-maximal inhibitory concentration: 12700 nM
Beside the measured number, compound 3's estimate is 3.2-fold (0.50 log units) below it; the measured number falls inside the stated range.
By their numbers in this assay, from the lowest: compounds 2 and 1 (each within the scatter of the next); then compound 3.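

Going by these compounds alone, the amine nitrogen in a ring now has its first measured step: in this assay, (4-chlorophenyl)sulfonyl in place of methyl gives a 2.8-fold higher number from compound 2 to compound 3 (0.45 log units; beyond the scatter), whereas the only earlier step, on the aromatic carbon, stayed within the scatter. This position therefore registers a change on this read-out, and here the change goes toward weaker inhibition, although a single pair carries that reading and no trend can be drawn from it. Nothing at hand accounts for the step.

On these data alone, whether the step goes with the sulfonyl link or with the 4-chlorophenyl ring stays open, since the two enter together. Also open, as far as these compounds go, is how an acetyl or a benzyl group on this nitrogen would read, and whether a plain phenylsulfonyl group would match compound 3.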